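Trading a Methoxy Group for a Fluoro Group

The source may hold more compounds than are shown below. What is called first, only, known or untested is meant among the compounds shown, and "the series" means these compounds.

Within the data shown here, in an ADME assay on the whole organism (Rattus norvegicus, strain Sprague-Dawley) for pharmacokinetics, read by LC-MS, at a dose of 5 mg/kg by the oral route (a higher number here means that a larger share of the oral dose reaches the circulation, a lower number that a smaller share of the oral dose reaches the circulation), compound 2 (`COc1ccccc1-c1cccc(-c2cc3nc(C)c([C@H](OC(C)(C)C)C(=O)O)c(-c4cc(F)c5c(c4C)CCCO5)n3n2)c1`) reaches 59% and so holds the higher of the two numbers measured so far, while compound 1 (`Cc1ccccc1-c1cccc(-c2cc3nc(C)c([C@H](OC(C)(C)C)C(=O)O)c(-c4cc(F)c5c(c4C)CCCO5)n3n2)c1`) reaches 32% in the same test. Compound 3 (`Cc1nc2cc(-c3cccc(-c4ccccc4F)c3)nn2c(-c2cc(F)c3c(c2C)CCCO3)c1[C@H](OC(C)(C)C)C(=O)O`) has not been measured yet. It differs from compound 2 in one group: fluoro in place of methoxy on an aromatic carbon, ortho to a large group (fluoro in place of methoxy on an aromatic carbon). Among the measured compounds shown here, only one measured step bears on this change, and it concerns the same place, with methoxy in place of methyl. That step is a number 27 percentage points higher from compound 1 to compound 2 (beyond the scatter) in this assay and shows that a swap at this place can move the number by a clear margin. Fluoro has not been measured there, so the best guess lies between compound 1 at 32% and compound 2 at 59% as a partial loss of that gain. The expected change is a number 14 percentage points lower from compound 2 to compound 3 (beyond the scatter) and this is held with little confidence. The expected value for compound 3 is 45% within an estimated range of 25% to 65% on this thin evidence.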

Compound 3, oral bioavailability: 44%
Compound 3: the middle estimate sits 1 percentage points above what was measured; low and high end bracket the measured number.
By their numbers in this assay, from the lowest: compound 1; then compound 3; then compound 2.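

In this assay, the swap from 2-methoxyphenyl to 2-fluorophenyl gives back part of the earlier gain, with a number 15 percentage points lower from compound 2 to compound 3 (beyond the scatter), yet fluoro still keeps an edge over methyl, with a number 12 percentage points higher from compound 1 to compound 3 (beyond the scatter). The three groups at this one place therefore fall into a clear order, with methoxy on top, fluoro in the middle and methyl at the bottom, and every step among them lies beyond the usual scatter. A rise over methyl at this place thus does not depend on the methoxy group alone, although nothing available here explains why these groups rank as they do.

The compounds shown leave open where chloro, a nitrile or a longer group such as ethoxy would fall in this order, and whether any of them would match or pass methoxy. They also leave open whether the same order would hold with these groups placed elsewhere on this ring, and which stage between the oral dose and the circulation accounts for the differences, since a single whole-animal number cannot separate those stages.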